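Adding a methyl to the ring nitrogen of compound 1

A few compounds are considered here, and "the series" means these few. Any claim that something is new, unique, unknown or untested is made for them only; others in the source may bear on it.

Three compounds measured so far in an ADME assay on MDBK cells (Bos taurus) for cytotoxicity, read by MTT assay, with a stated time of 96 h (a higher number here means that more compound is tolerated, a lower number that less compound is tolerated), are:
- Compound 1 `O=[N+]([O-])c1ccc(-c2nc3cc(C(F)(F)F)ccc3[nH]2)cc1` gives 6000 nM
- Compound 2 `O=[N+]([O-])c1ccc(-c2nc3cc(C(F)(F)F)ccc3[nH]2)c([N+](=O)[O-])c1` gives 16000 nM
- Compound 3 `Fc1ccc(-c2nc3cc(C(F)(F)F)ccc3[nH]2)cc1` gives 19000 nM

Compound 1 stands lowest of these three numbers, so it is the least tolerated of them. Compound 2 and compound 3 both lie above it, each by a gap beyond the scatter.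

Compound 4 `Cn1c(-c2ccc([N+](=O)[O-])cc2)nc2cc(C(F)(F)F)ccc21` has not been measured yet. Going by the values given here, its one change from compound 1 is methyl in place of hydrogen on an aromatic nitrogen.

Two measured steps offer a guide, though neither touches that nitrogen. The step of a 2.7-fold higher number from compound 1 to compound 2 (0.43 log units; beyond the scatter) goes with nitro in place of hydrogen on an aromatic carbon, and the step of a 3.2-fold higher number from compound 1 to compound 3 (0.50 log units; beyond the scatter) goes with fluoro in place of nitro on an aromatic carbon. Both are modest and both go upward, but they concern other places on the molecule, and three compounds make no rule.

A small upward step in this assay is therefore expected, no larger than those two: the estimated step is a 1.5-fold higher number from compound 1 to compound 4 (0.18 log units; within the scatter) and nothing firmer can be said. Among the compounds with values here, for compound 4 the estimated value is 9000 nM with an expected range of 3000 nM to 25000 nM and this range is kept wide: no measured step involves that nitrogen.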

Compound 4, half-maximal cytotoxic concentration: > 100000 nM
Compound 4: no number, only a limit; the forecaster's own chance of this, stated with the estimate: 10%; middle value at least 11-fold (1.04 log units) from the limit.
By their numbers in this assay, from the lowest: compound 1; then compounds 2 and 3 (each within the scatter of the next). At a limit, above all of these: compound 4.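

In this assay compound 4 gives > 100000 nM, which is a limit of the assay and not a number. Going by these compounds alone, this aromatic nitrogen of the five-membered ring is the first place where one small change has a large effect on how much compound is tolerated: a single methyl in place of hydrogen gives an at least 16-fold higher number from compound 1 to compound 4 (1.22 log units; beyond the scatter), whereas the two changes on aromatic carbons gave only the modest steps of a 2.7-fold higher number from compound 1 to compound 2 (0.43 log units; beyond the scatter) and a 3.2-fold higher number from compound 1 to compound 3 (0.50 log units; beyond the scatter). The direction of the new step is clear, but how far it reaches cannot be read from a limit: the limit of > 100000 nM in this assay, at which 1 of the 4 values shown sits.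

The compounds shown leave open whether the methyl itself matters or only the loss of the hydrogen on that nitrogen, a question that an ethyl group or a longer chain on the same nitrogen could help to separate. As far as these compounds go, it also remains open whether the same methyl would give a step of similar size on compound 2 or compound 3, since only the core of compound 1 carries it here.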